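Swapping the thiazole for an open-chain amidine group

The compounds below may be only part of what the source reports. "The series", "measured", "known", "first", "only" and "open" are said of these compounds alone.

Measured compounds:
- compound 1, `c1ccc2c(c1)CCC(CNCCCNC1=NCCCC1)O2`: 3.98 nM
- compound 2, `c1ccc2c(c1)CCC(CNCCCNc1nccs1)O2`: 7.94 nM

In an assay on isolated protein (Bos taurus) with 5-hydroxytryptamine receptor 1D (Homo sapiens) as the target (on this read-out lower numbers stand for stronger inhibition and higher numbers for weaker inhibition), compound 2 gives the higher of the two numbers, with compound 1 the nearest, and the gap a 2.0-fold higher number from compound 1 to compound 2 (0.30 log units; within the scatter) does not rise above the scatter of the method. Compound 3, `CC(C)/N=C(\N)NNCCCNCC1CCc2ccccc2O1`, has not yet been measured in this assay. It differs from compound 2 by a group of 7 heavy atoms (4 carbon, 3 nitrogen; no ring) in place of a group of 5 heavy atoms (3 carbon, 1 nitrogen, 1 sulfur; one five-membered aromatic ring with 2 hetero atoms), on an amine nitrogen. Within the data shown here, only one measured step touches the same place: a 2.0-fold higher number from compound 1 to compound 2 (0.30 log units; within the scatter), where a six-membered non-aromatic ring gave way to the thiazole with no change beyond the scatter. Among the measured compounds shown here, that single step is the only guide, and it shows two quite different groups at this position giving similar numbers. The expectation for compound 3 is therefore a step of a 1.0-fold higher number from compound 2 to compound 3 (0.00 log units; within the scatter), nothing beyond the scatter in either direction. The estimate for compound 3 in this assay is 8 nM, within a range from 2.5 nM to 25 nM.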

Compound 3, half-maximal inhibitory concentration: 3.16 nM
Compound 3: middle estimate off by 2.5-fold (0.40 log units), on the high side; the range from low to high includes it.
By their numbers in this assay, from the lowest: compounds 3, 1 and 2 (each within the scatter of the next, the first and the last beyond it).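

In this assay, among these compounds, the open-chain group on the amine nitrogen gives the first step at this position that lies beyond the scatter: a 2.5-fold lower number from compound 2 to compound 3 (0.40 log units; beyond the scatter), a modest change in favour of the group without a ring. Set against the six-membered non-aromatic ring, the same group gives a 1.3-fold lower number from compound 1 to compound 3 (0.10 log units; within the scatter), which stays within the scatter, so among these three compounds a ring at this position is not required for a number of this size. No measurement is available that would explain either step.

The compounds shown leave open whether a much smaller group, such as an acetyl group, would keep the number in this range on the same amine nitrogen. They also leave open how a phenyl ring would compare there with the thiazole.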